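A bromo group added to compound 1

The source may hold more compounds than are shown below. What is called first, only, known or untested is meant among the compounds shown, and "the series" means these compounds.

compound 1 `COc1ccc(/C=C2\Cc3c(cc(OC)c(OC)c3OC)C2=O)cc1` gives 560 nM
compound 2 `COc1cc(/C=C2\Cc3c(cc(OC)c(OC)c3OC)C2=O)cc(OC)c1OC` gives 1580 nM
compound 3 `COc1cc2c(c(OC)c1OC)C/C(=C\c1cc(OC)c(OC)c(OC)c1OC)C2=O` gives > 10000 nM (a limit)

In a functional assay on Bel-7402 cells (Homo sapiens) for antiproliferative activity, read by MTT assay, with a stated time of 48 h (a lower number here means a stronger inhibitor of growth, a higher number a weaker inhibitor of growth), compound 1 holds the lower of the two exact numbers, and compound 2 lies higher by more than the scatter. Compound 3 shows only a limit of the assay.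

Compound 4 `COc1ccc(/C=C2\Cc3c(cc(OC)c(OC)c3OC)C2=O)cc1Br` has bromo in place of hydrogen on an aromatic carbon of compound 1, ortho to a methoxy group bromo in place of hydrogen on an aromatic carbon and is still unmeasured. Among the compounds with values here, only one measured step bears on this, and loosely: methoxy in place of hydrogen gave an at least 6.3-fold higher number from compound 2 to compound 3 (0.80 log units; beyond the scatter) on a different compound. Bromo is a different group, so a smaller rise is expected, perhaps none beyond the scatter. The expected step is a 1.4-fold higher number from compound 1 to compound 4 (0.15 log units; within the scatter) in this assay for this change. For compound 4 the estimated value is 800 nM (range 250 nM to 3000 nM).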

Compound 4, concentration for 50% growth inhibition: 563 nM
Beside the measured number, compound 4's estimate is 1.4-fold (0.15 log units) above it; measured number inside the range.
By their numbers in this assay, from the lowest: compounds 1 and 4 (each within the scatter of the next); then compound 2. At a limit, above all of these: compound 3.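

In this assay, bromo in place of hydrogen on an aromatic carbon, ortho to a methoxy group, gives a 1.0-fold higher number from compound 1 to compound 4 (0.00 log units; within the scatter) and so leaves growth inhibition unchanged within the scatter. Within the data shown here, this position of compound 1 therefore accepts a bromine atom, whereas the only earlier step, a methoxy group added to compound 2, led to a limit of the assay. Nothing measured here explains why the bromo group is accepted. On these data alone, whether an amine or a carboxylic acid would be accepted at this position remains open.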